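Dropping the Chlorine: 4-Chlorophenyl to Phenyl

The compounds below may be only part of what the source reports. "The series", "measured", "known", "first", "only" and "open" are said of these compounds alone.

In a functional assay on MCF7 cells (Homo sapiens) for antiproliferative activity, read by MTT assay, with a stated time of 48 h (a lower number here means a stronger inhibitor, a higher number a weaker inhibitor), compound 2 `N#Cc1c(-c2ccc(Cl)cc2)nc2c(/N=N/c3ccc(S(N)(=O)=O)cc3)c(N)nn2c1N` gives 10300 nM and compound 1 `N#Cc1c(-c2ccc(F)cc2)nc2c(/N=N/c3ccc(S(N)(=O)=O)cc3)c(N)nn2c1N` gives 7730 nM, so the two sit within the scatter of each other. Compound 3 `N#Cc1c(-c2ccccc2)nc2c(/N=N/c3ccc(S(N)(=O)=O)cc3)c(N)nn2c1N` differs from compound 2 in one place: hydrogen in place of chloro on an aromatic carbon. This puts hydrogen in place of chloro on an aromatic carbon, turning 4-chlorophenyl to phenyl. Going by the values given here, only one measured step bears on this change: a 1.3-fold higher number from compound 1 to compound 2 (0.12 log units; within the scatter), which came from chloro in place of fluoro on an aromatic carbon. Among the compounds with values here, that step swaps one halogen for another, and no measurement yet compares a halogen with hydrogen, so it is only indirect evidence. Even so, no step beyond the scatter is expected in this assay, and the expected change is a 1.1-fold lower number from compound 2 to compound 3 (0.06 log units; within the scatter). For compound 3 the estimated value is 9000 nM, with an expected range of 4000 nM to 20000 nM.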

Compound 3, half-maximal inhibitory concentration: 960 nM
Estimate against measurement, compound 3: 9.4-fold (0.97 log units) above, and the stated range ends above it.
By their numbers in this assay, from the lowest: compound 3; then compounds 1 and 2 (each within the scatter of the next).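

In this assay the swap of one halogen for the other gave no step beyond the scatter, yet removing the halogen altogether gives an 11-fold lower number from compound 2 to compound 3 (1.03 log units; beyond the scatter) when chloro leaves, and an 8.1-fold lower number from compound 1 to compound 3 (0.91 log units; beyond the scatter) when fluoro leaves. This position on the aromatic ring therefore matters to the result: the two halogen compounds read alike, while the plain phenyl of compound 3 stands apart from both. A step between two halogens turns out to be a poor guide to a step from halogen to hydrogen, so the earlier comparison hid how much this change could do.

Going by these compounds, whether a methyl, a methoxy or an amine at this position would stay close to compound 3 or fall back towards the halogen compounds remains open. Nothing available here explains why hydrogen differs so clearly from both halogens.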